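Biaryl amide series: ring substituent swap at compound 4

This account rests on a few compounds, and the source may have more. Where it says the series, first, only, none or still open, it means among the compounds named here.

Measured compounds in a functional assay for antagonist activity at transient receptor potential cation channel subfamily V member 1 (Homo sapiens), read by FLIPR; on this read-out lower numbers stand for stronger inhibition and higher numbers for weaker inhibition:
- compound 1 `CCCNc1cccnc1-c1ccc(C(=O)Nc2ccc(C(C)(C)C)cc2)cc1` gives 158 nM
- compound 2 `CCS(=O)(=O)Nc1cccnc1-c1ccc(C(=O)Nc2ccc(C(C)(C)C)cc2)cc1` gives 49 nM
- compound 3 `CN(C)Cc1cccnc1-c1ccc(C(=O)Nc2ccc(C(C)(C)C)cc2)cc1` gives 746 nM

Compound 3 holds the highest number of the three: the step of a 4.7-fold higher number from compound 1 to compound 3 (0.67 log units; beyond the scatter) and the step of a 15-fold higher number from compound 2 to compound 3 (1.18 log units; beyond the scatter) both lie beyond the scatter, so compound 3 is the least potent of the measured set. Among the measured steps, a 3.2-fold lower number from compound 1 to compound 2 (0.51 log units; beyond the scatter) shows that changing the substituent on the shared core moves this assay by a modest amount, and the steps to compound 3 show the widest span.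

Compound 4 `CC(C)(C)c1ccc(NC(=O)c2ccc(-c3ncccc3-c3nnco3)cc2)cc1` differs from compound 3 by 1,3,4-oxadiazol-2-yl in place of (dimethylamino)methyl on an aromatic carbon. For the measured compounds named here, no measured step covers this replacement directly; the measured steps only show that the site tolerates substituent changes with modest to large effects, and that compound 3 sits at the weak end. A return toward the numbers of compound 1 and compound 2 is therefore expected rather than a further rise. The expected step is a 3.7-fold lower number from compound 3 to compound 4 (0.57 log units; beyond the scatter), though its size is uncertain. For compound 4 the expected value in this assay is 200 nM, with a range from 50 nM to 800 nM.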

Compound 4, half-maximal inhibitory concentration: 91 nM
Beside the measured number, compound 4's estimate is 2.2-fold (0.34 log units) above it; measured number inside the range.
By their numbers in this assay, from the lowest: compounds 2, 4 and 1 (each within the scatter of the next, the first and the last beyond it); then compound 3.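

Notes on this position, read in this assay: 1,3,4-oxadiazol-2-yl is the only ring among the groups shown on this aromatic carbon, ortho to a large group, and it replaces (dimethylamino)methyl with a clear recovery (an 8.2-fold lower number from compound 3 to compound 4 (0.91 log units; beyond the scatter)). The two open-chain nitrogen-linked groups do not separate from it (a 1.9-fold higher number from compound 2 to compound 4 (0.27 log units; within the scatter); a 1.7-fold lower number from compound 1 to compound 4 (0.24 log units; within the scatter)), so compound 4 cannot be ranked against compound 1 or compound 2, although those two differ from each other beyond the scatter. The position therefore accepts a five-membered aromatic ring as well as those chains, and among the four compounds only compound 3 stands apart on the weak side.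

As far as these compounds go, whether a carboxylic acid, a nitrile or a five-membered aromatic ring with other hetero atoms would hold this level remains open. Nothing at hand explains the recovery from compound 3 to compound 4.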